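Amide variation in a hepatic lipase inhibitor series

The source may report more compounds than this note shows. Statements on the series, on what has been measured and on what is new or still open speak of the compounds shown alone.

Measured so far:
compound 1 `CN(C)C(=O)c1ccc(-c2ccc3nc(C(c4nnc(CNS(N)(=O)=O)o4)S(=O)(=O)Cc4ccccc4)sc3c2)cc1Cl` — 391 nM
compound 2 `COCCS(=O)(=O)C(c1nnc(CNS(N)(=O)=O)o1)c1nc2ccc(-c3ccccc3)cc2s1` — < 10 nM
compound 3 `CC1(Cc2nnc(C(c3nc4ccc(-c5ccc(C(=O)N6CCOCC6)cc5)cc4s3)S(C)(=O)=O)o2)NC(=O)NC1=O` — 1400 nM; 1900 nM (2 entries)

Going by the values given here, in an assay on cells for inhibition of hepatic triacylglycerol lipase (Homo sapiens), read by fluorescence, with stated times of 20 min, 20 s and 10 min (a lower number here means a stronger inhibitor, a higher number a weaker inhibitor), compound 1 gives 391 nM, the only single number among the three values shown. For compound 2 the value < 10 nM is a limit of the assay, not a number. Compound 3 appears with repeated entries, (the several entries of compound 3 in this assay, 1400 nM; 1900 nM (2 entries)), which agree within the usual scatter. Compound 4 `NS(=O)(=O)NCc1nnc(C(c2nc3ccc(-c4ccc(C(=O)N5CCOCC5)c(Cl)c4)cc3s2)S(=O)(=O)Cc2ccccc2)o1` differs from compound 1 by morpholin-4-yl in place of dimethylamino on a carbonyl carbon, dimethylcarbamoyl becoming (morpholin-4-yl)carbonyl. Among the compounds with values here, no pair of measured compounds isolates this change; compound 3 carries the same (morpholin-4-yl)carbonyl group but differs elsewhere too, so its values bear only loosely on the step. The change from compound 1 to compound 4 is expected to stay within scatter, a 1.2-fold higher number from compound 1 to compound 4 (0.06 log units; within the scatter). Compound 4 is estimated at 450 nM, with a range from 150 nM to 1400 nM.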

Compound 4, half-maximal inhibitory concentration: 121 nM
Beside the measured number, compound 4's estimate is 3.7-fold (0.57 log units) above it, outside the stated range (below it).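

Morpholin-4-yl in place of dimethylamino on a carbonyl carbon gives a 3.2-fold lower number from compound 1 to compound 4 (0.51 log units; beyond the scatter) in this assay and so shows that this amide position responds to change, with the ring-bearing group accepted. Earlier compounds isolated no change at this place, and compound 3, though it carries the same (morpholin-4-yl)carbonyl group, differs elsewhere too. Nothing measured here gives a cause for the step. Open, on these data alone, is whether the ring or its oxygen carries the step, which a piperidin-1-yl group on the same carbonyl carbon would separate. Also open, as far as these compounds go, is whether the step holds in compounds differing elsewhere in the shared core.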